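Trimming the chain end of compound 1

The compounds below may be only part of what the source reports. "The series", "measured", "known", "first", "only" and "open" are said of these compounds alone.

Measured so far:
compound 1, `CC/N=C(/NC#N)NCCCCn1nc(-c2ccccc2)ccc1=O`: in a functional assay on the whole organism (stomach) with Rattus norvegicus as the target (on this read-out lower numbers stand for an effect already at smaller amounts and higher numbers for an effect only at larger amounts of compound), compound 1 gives 92 mg/kg.
compound 2, `CC/N=C(/NC#N)NCCCCn1nc(-c2ccccc2)c(C)cc1=O`: in this assay compound 2 reaches only a limit of the assay, > 100 mg/kg.

Among the measured compounds shown here, compound 1 stands as the only compound with an actual number in this assay; the other value is a limit, which gives no number to compare with. Compound 3, `N#CNC(=N)NCCCCn1nc(-c2ccccc2)ccc1=O`, differs from compound 1 by a group of 5 heavy atoms (2 carbon, 3 nitrogen; no ring) in place of a group of 7 heavy atoms (4 carbon, 3 nitrogen; no ring), on an amine nitrogen. For the measured compounds named here, the single measured step, an at least 1.0-fold higher number from compound 1 to compound 2 (0.03 log units; that floor lies within the scatter), concerns a methyl on an aromatic carbon of the shared core and leaves the amine nitrogen untouched, so it does not bear on the change toward compound 3; moreover compound 2 sits at the limit of > 100 mg/kg in this assay, at which 1 of the 2 values shown sits, so even that step is known only as a floor within the scatter. Going by the values given here, no measured step therefore speaks to the size of the present change. With nothing to push the expectation in either direction, compound 3 is expected to show no step beyond the scatter, and the step from compound 1 is estimated as a 1.1-fold higher number from compound 1 to compound 3 (0.04 log units; within the scatter). Compound 3 is thus estimated at 100 mg/kg, with a range from 40 mg/kg to 300 mg/kg.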

Compound 3, dose for half-maximal effect: 77.2 mg/kg
Compound 3: the middle estimate sits 1.3-fold (0.11 log units) above what was measured; low and high end bracket the measured number.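

Among the compounds shown here, the first measured change on the amine nitrogen, a group of 5 heavy atoms in place of a group of 7 heavy atoms, gives a 1.2-fold lower number from compound 1 to compound 3 (0.08 log units; within the scatter) in this assay. At this position, then, the two groups cannot be told apart on this read-out, even though the entering group counts 2 hydrogen-bond donors against 1 in the group that leaves. Unlike the methyl step to compound 2, which rests on a limit of the assay, this step joins two actual numbers and can be read directly, but nothing shown gives a cause for it.

For the compounds shown here, what happens with a larger or differently built group on this amine nitrogen, such as a longer chain or a benzyl group, stays open, since the two groups compared here give only one step and it lies within the scatter. Also open, going by these compounds, is whether the same group change would leave the number as it is on a core carrying the methyl of compound 2, or with a carboxylic acid at the chain end in place of the nitrile.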